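Hydroxy in place of hydrogen on compound 1

A few compounds are considered here, and "the series" means these few. Any claim that something is new, unique, unknown or untested is made for them only; others in the source may bear on it.

In a functional assay on A549 cells (Homo sapiens) for cytotoxicity, read by sulforhodamine B assay, with a stated time of 72 h (on this read-out lower numbers stand for stronger inhibition of growth and higher numbers for weaker inhibition of growth), compound 1 (`C=C1CC[C@@H]2[C@](C)(CCC[C@]2(C)C(=O)OC)[C@H]1CCc1ccc2c(OC)ccc(OC)c2c1`) gives > 6700 nM, which is a limit and not a number. Compound 3 (`C=C1[C@H](O)C[C@@H]2[C@](C)(CCC[C@]2(C)C(=O)OC)[C@H]1CCc1ccc2c(OC)ccc(OC)c2c1`) gives > 6400 nM, also a limit. Among the measured compounds shown here, compound 2 (`C=C1CC[C@@H]2[C@](C)(CCC[C@]2(C)C(=O)OCc2ccccc2)[C@H]1CCc1ccc2c(OCc3ccccc3)ccc(OCc3ccccc3)c2c1`) reads 6500 nM, the only true number so far. Compound 4 (`C=C1CC[C@@H]2[C@](C)(CCC[C@]2(C)C(=O)OC)[C@]1(O)CCc1ccc2c(OC)ccc(OC)c2c1`) differs from compound 1 by hydroxy in place of hydrogen on a saturated ring carbon. For the measured compounds named here, the one measured step of this kind is a step that the two limits leave unreadable from compound 1 to compound 3. Going by the values given here, with that step as the only guide, and its size unreadable, no change beyond the scatter is expected in this assay. The expected step is an at least 1.0-fold lower number from compound 1 to compound 4 (0.01 log units; that floor lies within the scatter). Compound 4 is estimated at 6500 nM, with an expected range of 3000 nM to 10000 nM, and a report as a limit only is likely.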

Compound 4, concentration for 50% growth inhibition: > 21500 nM
Compound 4: only a limit was reported; the forecaster's own chance of this, stated with the estimate: 75%; middle value at least 3.3-fold (0.51 log units) away from the limit.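

In this assay compound 1 gives the limit > 6700 nM. Among the compounds shown here, compound 4 gives the limit > 21500 nM, so no step from compound 1 to compound 4 can be read. On these data alone, whether hydroxy in place of hydrogen on a saturated ring carbon changes growth inhibition remains open.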